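From difluorophenyl to dimethylphenyl on a sulfonamide nitrogen

The source may hold more compounds than are shown below. What is called first, only, known or untested is meant among the compounds shown, and "the series" means these compounds.

Measured in a functional assay on M21 cells (Homo sapiens) for antiproliferative activity, read by sulforhodamine B assay, with a stated time of 48 h; on this read-out lower numbers stand for stronger inhibition and higher numbers for weaker inhibition:
- compound 1 `O=C1NCCN1c1ccc(S(=O)(=O)Nc2ccc(F)cc2)cc1`: 230 nM
- compound 2 `Cc1ccc(NS(=O)(=O)c2ccc(N3CCNC3=O)cc2)cc1C`: 94 nM
- compound 3 `O=C1NCCN1c1ccc(S(=O)(=O)Nc2ccc(F)c(F)c2)cc1`: 220 nM

Not yet measured: compound 4 `Cc1cc(C)cc(NS(=O)(=O)c2ccc(N3CCNC3=O)cc2)c1`.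

In this assay compound 3 gives 220 nM, the second highest of the three numbers. It lies within the scatter of compound 1, a 1.0-fold lower number from compound 1 to compound 3 (0.02 log units; within the scatter), while the other neighbour is clearly apart, a 2.3-fold higher number from compound 2 to compound 3 (0.37 log units; beyond the scatter). The change now followed is 3,5-dimethylphenyl in place of 3,4-difluorophenyl on a sulfonamide nitrogen. Going by the values given here, no measured compound carries the 3,5-dimethylphenyl group, so its effect is untested. The nearest evidence is compound 2, the 3,4-dimethylphenyl analogue, with its modest steps of a 2.4-fold lower number from compound 1 to compound 2 (0.39 log units; beyond the scatter) and a 2.3-fold higher number from compound 2 to compound 3 (0.37 log units; beyond the scatter). Compound 4 is therefore expected to fall toward compound 2, though perhaps not fully. A modest move to a lower number is expected in this assay, estimated as a 1.8-fold lower number from compound 3 to compound 4 (0.25 log units; within the scatter). The estimated value for compound 4 is 125 nM, with an expected range from 55 nM to 280 nM.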

Compound 4, half-maximal inhibitory concentration: 63 nM
Beside the measured number, compound 4's estimate is 2.0-fold (0.30 log units) above it; measured number inside the range.
By their numbers in this assay, from the lowest: compounds 4 and 2 (each within the scatter of the next); then compounds 3 and 1 (each within the scatter of the next).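

In this assay, 3,5-dimethylphenyl in place of 3,4-difluorophenyl on the sulfonamide nitrogen gives a 3.5-fold lower number from compound 3 to compound 4 (0.54 log units; beyond the scatter), and the same group in place of 4-fluorophenyl gives a 3.7-fold lower number from compound 1 to compound 4 (0.56 log units; beyond the scatter). With 3,5-dimethylphenyl in place of 3,4-dimethylphenyl, the result is a 1.5-fold lower number from compound 2 to compound 4 (0.17 log units; within the scatter), so among these four compounds both dimethylphenyl groups sit apart from both fluorinated groups, and no compound goes against this. Nothing available explains this separation.

As far as these compounds go, it remains open whether 3,5-difluorophenyl would read with the fluorinated pair or with the dimethylphenyl pair, which would help separate the choice of atoms from their placement on the ring. From the compounds shown here alone, how a single methyl, an ethyl or a methoxy group would read on this ring also remains open.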